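From a Limit to 1,3-Benzothiazol-6-yl in Compound 4

The source may report more compounds than this note shows. Statements on the series, on what has been measured and on what is new or still open speak of the compounds shown alone.

Of the compounds shown here, three have been measured in a functional assay on MCF7 cells (Homo sapiens) for antiproliferative activity, read by CellTiter-Glo, with a stated time of 5 days; a higher number here means a weaker inhibitor, a lower number a stronger inhibitor. Compound 1 `CC/C(=C(/c1ccc(/C=C/C(=O)O)cc1)c1ccc2c(cnn2C)c1)c1ccc(F)cc1Cl` gives 81 nM, and compound 2 `CC/C(=C(/c1ccc(/C=C/C(=O)O)cc1)c1ccc2nccn2c1)c1ccccc1` gives 170 nM. Compound 3 `CC/C(=C(/c1ccc(/C=C/C(=O)O)cc1)c1ccc2cncn2c1)c1ccccc1` gives > 500 nM, which is a limit of the assay and not a number. Its standing is therefore only (the limit of > 500 nM in this assay, at which 1 of the 3 values shown sits).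

Compound 4 `CC/C(=C(/c1ccc(/C=C/C(=O)O)cc1)c1ccc2ncsc2c1)c1ccccc1` differs from compound 3 by a group of 9 heavy atoms (7 carbon, 1 nitrogen, 1 sulfur; one five-membered aromatic ring with 2 hetero atoms, one six-membered aromatic ring of carbon only) in place of a group of 9 heavy atoms (7 carbon, 2 nitrogen; one five-membered aromatic ring with 2 hetero atoms, one six-membered aromatic ring with 1 hetero atom), on a double-bonded chain carbon bound to an aromatic carbon and a double-bonded chain carbon. The entering group is 1,3-benzothiazol-6-yl, and it sits on a double-bonded chain carbon bound to an aromatic carbon and a double-bonded chain carbon.

For the measured compounds named here, one measured step bears on this change, at that same place: an at least 2.9-fold higher number from compound 2 to compound 3 (0.46 log units; beyond the scatter). That step lies beyond the scatter, so a swap of this group can shift the result in this assay, and a shift beyond the scatter is expected here too. The direction expected is towards a lower number, resting on compound 2 at 170 nM, which carries a group of the same size at that place. The size is uncertain, as the starting point is only a limit, and a result at the limit remains possible.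

The expected change is an at least 3.3-fold lower number from compound 3 to compound 4 (0.52 log units; beyond the scatter). Compound 4 is expected at 150 nM, with an estimated range of 45 nM to 500 nM.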

Compound 4, half-maximal inhibitory concentration: > 500 nM
Compound 4: only a limit was reported; the forecaster's own chance of this, stated with the estimate: 15%; middle value at least 3.3-fold (0.52 log units) from the limit.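

In this assay compound 4 gives > 500 nM, which is a limit of the assay and not a number, and the step from compound 3, itself held at a limit, cannot be read. The step that can be read is an at least 2.9-fold higher number from compound 2 to compound 4 (0.46 log units; beyond the scatter), so a second group of the same heavy-atom count, 1,3-benzothiazol-6-yl, now stands apart from the group of compound 2 at this place, on a double-bonded chain carbon bound to an aromatic carbon and a double-bonded chain carbon. Before this result only the group of compound 3 had shown such a separation, and among the compounds that differ here only at this place, compound 2 alone now has a number, while the limit has gained a second compound: the limit of > 500 nM in this assay, at which 2 of the 4 values shown sit.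

On these data alone, how far compound 3 and compound 4 lie beyond the limit remains unknown, so no order can be given between them. As far as these compounds go, it also remains open whether an amine or a methoxy group carried on the 1,3-benzothiazol-6-yl group would bring the result in this assay back towards that of compound 2.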